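Swapping the aryl cap for a fluorinated benzyl group

The source may hold more compounds than are shown below. What is called first, only, known or untested is meant among the compounds shown, and "the series" means these compounds.

Of the compounds shown here, two have been measured in a functional assay on Mahlavu cells (Homo sapiens) for antiproliferative activity, read by sulforhodamine B assay, with a stated time of 72 h; on this read-out higher numbers stand for weaker inhibition and lower numbers for stronger inhibition. Compound 1 `FC(F)(F)c1ccc(CN2CCN(Cc3cc(-c4ccc(OCc5cccc(Cl)c5)cc4)on3)CC2)cc1` gives 4100 nM. Compound 2 `N#Cc1cccc(COc2ccc(-c3cc(CN4CCN(c5ccc(C(F)(F)F)cc5)CC4)no3)cc2)c1` gives 2700 nM, the lowest of the two numbers, though the gap to compound 1 lies within the usual scatter, so the two cannot be ranked. Compound 3 `N#Cc1cccc(COc2ccc(-c3cc(CN4CCN(Cc5ccccc5F)CC4)no3)cc2)c1` has not yet been measured. It differs from compound 2 in one place: 2-fluorobenzyl in place of 4-(trifluoromethyl)phenyl on an amine nitrogen in a ring. Among the measured compounds shown here, no measured pair isolates this change, so there is no step to lean on. Since compound 1, which also carries a benzyl group on that ring nitrogen, gives 4100 nM, nothing in the data points to a shift beyond the scatter. The step from compound 2 to compound 3 in this assay is therefore expected to be small, a 1.3-fold higher number from compound 2 to compound 3 (0.11 log units; within the scatter). Compound 3 is estimated at 3500 nM, within a range from 1200 nM to 10000 nM.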

Compound 3, half-maximal inhibitory concentration: 2300 nM
Compound 3: middle estimate off by 1.5-fold (0.18 log units), on the high side; the range from low to high includes it.
By their numbers in this assay, from the lowest: compounds 3, 2 and 1 (each within the scatter of the next).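

In this assay, among the compounds shown here, this pair isolates the change for the first time, and the swap gives a 1.2-fold lower number from compound 2 to compound 3 (0.07 log units; within the scatter), which lies within the scatter. On this amine nitrogen in a ring, 2-fluorobenzyl and 4-(trifluoromethyl)phenyl therefore cannot be told apart, even though the two groups differ in heavy atoms, in fluorine count and in how the aromatic ring is attached. Nothing available accounts for this result.

As far as these compounds go, it remains open whether a plain methyl on this ring nitrogen, with no aromatic ring at all, or an amine or a carboxylic acid on the benzyl ring would shift the number beyond the scatter. From the compounds shown here alone, it is also open whether the swap would stay this small with a different group elsewhere on the shared core.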